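A few compounds are considered here, and "the series" means these few. Any claim that something is new, unique, unknown or untested is made for them only; others in the source may bear on it.

In an assay on HL-60 cells for inhibition of glutathione S-transferase P (Homo sapiens), read by spectrophotometry, tested at 5 uM (on this read-out higher numbers stand for more inhibition at the one concentration tested (going by the name of the read-out) and lower numbers for less inhibition), compound 3 `C=C(CC)C(=O)c1ccc(OCc2nc(-c3ccc4ccccc4c3)cs2)c(C)c1C` gives 0%, the lowest of the three measured numbers. Its nearest neighbour is compound 2 `C=C(CC)C(=O)c1ccc(OCc2nc(-c3ccc([N+](=O)[O-])cc3)cs2)c(C)c1C`, which in this assay gives 4.4%; the step of a number 4.4 percentage points lower from compound 2 to compound 3 (within the scatter) lies within the scatter. Compound 1 `C=C(C)C(=O)c1ccc(OCc2nc(-c3ccccc3)cs2)c(C)c1C` stands far apart, giving 100% in this assay, but it differs from compound 3 in more than one place, so only the two values themselves can be set side by side. Compound 4 `C=C(CC)C(=O)c1ccc(OCc2nc(-c3ccc(C(F)(F)F)cc3)cs2)c(C)c1C` has not yet been measured in this assay. It differs from compound 3 by 4-(trifluoromethyl)phenyl in place of naphthalen-2-yl on an aromatic carbon. For the measured compounds named here, the one measured step that bears on this change is the earlier exchange of one aryl group on the aromatic carbon of the five-membered aromatic ring with 1 nitrogen and 1 sulfur, a number 4.4 percentage points lower from compound 2 to compound 3 (within the scatter), a change within the scatter. Going from naphthalen-2-yl to 4-(trifluoromethyl)phenyl is therefore expected to give a number 5 percentage points higher from compound 3 to compound 4 (within the scatter), nothing beyond the scatter. Compound 4 is estimated at 5% in this assay, with a range from 0% to 20%.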

Compound 4, a percentage reported as inhibition, at one concentration (the size of the read-out at that concentration, not a potency): 0%
Beside the measured number, compound 4's estimate is 5 percentage points above it; measured number inside the range.
By their numbers in this assay, from the lowest: compounds 3, 4 and 2 (each within the scatter of the next); then compound 1.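

In this assay, the exchange of the two-ring naphthalen-2-yl for the one-ring 4-(trifluoromethyl)phenyl, which has the same heavy-atom count, gives no change at the digits printed from compound 3 to compound 4 (within the scatter), and the exchange on the phenyl ring gives a number 4.4 percentage points lower from compound 2 to compound 4 (within the scatter). The earlier compounds shown here offered a single comparison at this aromatic carbon next to the ring nitrogen; now naphthalen-2-yl, 4-nitrophenyl and 4-(trifluoromethyl)phenyl on the shared core all lie within the scatter of one another. Nothing available here accounts for this.

From the compounds shown here alone, what a plain phenyl would give on the core of compound 4 stays open, since compound 1, at 100%, carries phenyl but differs from it in more than one place. Also open, going by these compounds, is how a phenyl ring bearing an amine or a carboxylic acid would read at this position.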